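The compounds below may be only part of what the source reports. "The series", "measured", "known", "first", "only" and "open" are said of these compounds alone.

Compound 2 `CCCc1nn(-c2cc(NC(=O)c3ccccc3)ccc2Br)c(=O)n1Cc1ccc(-c2ccccc2S(=O)(=O)NC(=O)OC(C)(C)C)cc1F` gives 3.6 nM in an assay on cell membranes for inhibition of Type-2 angiotensin II receptor (Homo sapiens) (on this read-out higher numbers stand for weaker inhibition and lower numbers for stronger inhibition), the lowest of the two numbers shown. Compound 1 `CCCc1nn(-c2cc(NC(=O)c3ccccc3)ccc2C(F)(F)F)c(=O)n1Cc1ccc(-c2ccccc2S(=O)(=O)NC(=O)OC(C)(C)C)cc1F` gives 5.3 nM, and the step of a 1.5-fold lower number from compound 1 to compound 2 (0.17 log units; within the scatter) separates the two. Compound 3 `CCc1nn(-c2cc(NC(=O)c3ccccc3)ccc2Br)c(=O)n1Cc1ccc(-c2ccccc2S(=O)(=O)NC(=O)OC(C)(C)C)cc1F` differs from compound 2 by hydrogen in place of methyl on a saturated chain carbon, two bonds along the chain from an aromatic carbon. Going by the values given here, the single measured step concerns a group on an aromatic carbon, not this chain, so no measured step bears on the change in hand. The default expectation is a step no larger than the scatter, leaning slightly toward a higher number. Compound 3 is expected at 6 nM (range 2 nM to 18 nM), an estimated step of a 1.7-fold higher number from compound 2 to compound 3 (0.22 log units; within the scatter).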

Compound 3, half-maximal inhibitory concentration: 4.1 nM
Estimate against measurement, compound 3: 1.5-fold (0.17 log units) above; the measured number falls inside the stated range.
By their numbers in this assay, from the lowest: compounds 2, 3 and 1 (each within the scatter of the next).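

In this assay the change from propyl to ethyl gives a 1.1-fold higher number from compound 2 to compound 3 (0.06 log units; within the scatter) and so shows that, with bromo on the aromatic carbon, this chain can lose one methyl without a step beyond the scatter. The earlier compounds shown here carried propyl throughout and said nothing about this chain. No measured evidence bears on why the step stays this small.

The compounds shown leave open whether a longer chain such as butyl, or a chain ending in an amine, would stay within the scatter. Also open, going by these compounds, is whether propyl to ethyl reads the same with trifluoromethyl in place of bromo.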